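A Chloro Step Weighed Against Cell Toxicity

A few compounds are considered here, and "the series" means these few. Any claim that something is new, unique, unknown or untested is made for them only; others in the source may bear on it.

Compound 1 `COc1ccc(-c2cnc(NC(=O)c3ccno3)n2C)cc1` — > 100000 nM
Compound 2 `COc1ccc(-c2cnc(NC(=O)c3ccccc3)n2C)cc1` — > 100000 nM

Compound 1 `COc1ccc(-c2cnc(NC(=O)c3ccno3)n2C)cc1` was tested in a toxicity assay on THP-1 cells (Homo sapiens) for inhibition; on this read-out lower numbers stand for higher toxicity in this test and higher numbers for lower toxicity in this test. In this assay compound 1 gives > 100000 nM, which is a limit of the assay and not a number. Compound 2 `COc1ccc(-c2cnc(NC(=O)c3ccccc3)n2C)cc1` likewise reaches only a limit in this assay, namely > 100000 nM. The step that the two limits leave unreadable from compound 1 to compound 2 cannot be read because of the limit of > 100000 nM in this assay, at which 2 of the 2 values shown sit. Compound 2 thus stands at the limit; neither value shown is a measured number, and no readable step exists among the measured compounds.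

Compound 3 `COc1ccc(-c2cnc(NC(=O)c3ccccc3Cl)n2C)cc1` differs from compound 2 by chloro in place of hydrogen on an aromatic carbon. For the measured compounds named here, no measured step bears on this change: the single step between measured compounds concerns a different place and is itself unreadable. In this assay the step expected is a number no higher from compound 2 to compound 3 (the limit leaves the size open), nothing beyond the scatter. Compound 3 is estimated at 100000 nM, ranging from 40000 nM to 300000 nM, most likely reported again as a limit.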

Compound 3, half-maximal cytotoxic concentration: > 50000 nM
Compound 3: a limit, no number; the forecaster's own chance of this, stated with the estimate: 75%; the middle value does not contradict the limit.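

In this assay compound 3 gives > 50000 nM, which is a limit of the assay and not a number. For the compounds shown here, with all three values being limits, no step from compound 1 or compound 2 to compound 3 can be read. The compounds shown leave open whether chloro in place of hydrogen changes toxicity in this test at all.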